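A few compounds are considered here, and "the series" means these few. Any claim that something is new, unique, unknown or untested is made for them only; others in the source may bear on it.

Among the compounds with values here, compound 1 `Cc1nn([C@H](C)c2ccc(Cl)cc2Cl)c2nc(N3CC[C@H](N4CCC[C@H]4CCS(C)(=O)=O)[C@H](C)C3)cnc12` is tested in a functional assay on cells for antagonist activity at C-C chemokine receptor type 4 (Homo sapiens), read by fluorescence and calcium flux, with stated times of 2.5 s and 45 s (a lower number here means a stronger inhibitor, a higher number a weaker inhibitor), where compound 1 gives 104 nM, the highest of the three numbers measured so far. Compound 2 `C[C@@H](Nc1cncc(C2=CCN(C(=O)[C@H]3CCCCN3)CC2)n1)c1ccc(Cl)cc1Cl` gives 54 nM in this assay, a gap from compound 1 that stays within the scatter, so these two cannot be ordered. Compound 3 `C[C@@H]1CC(c2cnc3c(C#N)nn([C@H](C)c4ccc(Cl)cc4Cl)c3n2)=CC[C@@H]1N1CCC[C@H]1C` gives 34 nM in this assay, and its gap to compound 1 lies beyond the scatter. Compound 4 `Cc1nn([C@H](C)c2ccc(Cl)cc2Cl)c2nc(N3CC[C@H](N4CCC[C@H]4C(=O)O)[C@H](C)C3)cnc12` differs from compound 1 at one site: carboxy in place of 2-(methylsulfonyl)ethyl on a saturated ring carbon. Within the data shown here, no measured pair shows this change, so nothing here sets its size; a modest shift toward a higher number is expected, though it may stay within the scatter. The step from compound 1 to compound 4 is estimated at a 1.9-fold higher number from compound 1 to compound 4 (0.28 log units; within the scatter). Compound 4 is expected to give about 200 nM in this assay, within a range from 50 nM to 800 nM.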

Compound 4, half-maximal inhibitory concentration: 670 nM
Compound 4: the middle estimate sits 3.4-fold (0.53 log units) below what was measured, and the stated range covers the measured number.
By their numbers in this assay, from the lowest: compounds 3, 2 and 1 (each within the scatter of the next, the first and the last beyond it); then compound 4.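

In this assay, within the data shown here, carboxy in place of 2-(methylsulfonyl)ethyl gives a 6.4-fold higher number from compound 1 to compound 4 (0.81 log units; beyond the scatter), the only single-site step so far. The group on this saturated ring carbon, next to the ring nitrogen, therefore matters: this one exchange moves the number beyond the scatter. Nothing at hand explains the size of the step. Still open, on these data alone, is how a primary amide, a methyl ester or a longer chain ending in a carboxylic acid would read at this carbon. Also open, as far as these compounds go, is whether the methylsulfonyl group or the ethyl chain carries the value of compound 1.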